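Aryl amide variation and cytotoxicity in the quinoline ether series

A few compounds are considered here, and "the series" means these few. Any claim that something is new, unique, unknown or untested is made for them only; others in the source may bear on it.

Compound 1 `COc1ccc(NC(=O)COc2cc(C)nc3ccc(OC)cc23)cc1` stands at the upper edge of what has been seen in a toxicity assay on HepG2 cells (Homo sapiens) for inhibition, read by CellTiter-Glo, with a stated time of 48 h; a higher number here means a weaker inhibitor, a lower number a stronger inhibitor: compound 1 gives > 100000 nM, which is a limit of the assay and not a read number. Compound 3 `COc1ccc2nc(C)cc(OCC(=O)Nc3ccncn3)c2c1` in this assay gives > 100000 nM, likewise a limit. For the measured compounds named here, compound 2 `COc1ccc2nc(C)cc(OCC(=O)Nc3ccc(Br)c(C)c3)c2c1` is the only member with a read value, 15900 nM in this assay. Exchanging the aryl amide gives an at least 6.2-fold lower number from compound 1 to compound 2 (0.79 log units; beyond the scatter), and the reverse direction gives an at least 6.2-fold higher number from compound 2 to compound 3 (0.79 log units; beyond the scatter). The step that the two limits leave unreadable from compound 1 to compound 3 cannot be sized because of the limit of > 100000 nM in this assay, at which 2 of the 3 values shown sit.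

Compound 4 `COc1ccc2nc(C)cc(OCC(=O)Nc3ccc(S(=O)(=O)Nc4cc(C)on4)cc3)c2c1` differs from compound 1 in a single place: (5-methyl-1,2-oxazol-3-yl)sulfamoyl in place of methoxy on an aromatic carbon. Going by the values given here, no measured step alters this position; the three measured steps all exchange the whole aryl group on the amide nitrogen, and only the halogenated phenyl of compound 2 pulled the number down into the readable range. Among the compounds with values here, a larger substituent on the retained methoxyphenyl ring has no measured precedent here, so the expected step of a number no higher from compound 1 to compound 4 (the limit leaves the size open) is small, with a number most likely again reported only as a limit. Compound 4 is therefore expected to give 100000 nM in this assay, within a range from 30000 nM to 300000 nM.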

Compound 4, half-maximal inhibitory concentration: > 100000 nM
Compound 4: only a limit was reported (the forecaster's own chance of this, stated with the estimate: 70%); the middle value sits exactly at the limit.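

Compound 4 gives > 100000 nM in this assay, which is a limit and not a number. No step from compound 1 to compound 4 can be read, because both compounds rest at the same limit: the limit of > 100000 nM in this assay, at which 3 of the 4 values shown sit.

The compounds shown leave open whether (5-methyl-1,2-oxazol-3-yl)sulfamoyl in place of methoxy changes the number at all.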